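Cytotoxicity notes on a small matched series

This account rests on a few compounds, and the source may have more. Where it says the series, first, only, none or still open, it means among the compounds named here.

Measured so far in an ADME assay on Vero cells (Chlorocebus sabaeus) for cytotoxicity, read by MTT assay, with a stated time of 96 h; on this read-out higher numbers stand for lower toxicity in this test and lower numbers for higher toxicity in this test:
- compound 1 `CC(=O)c1ccc2c(c1)nc(-c1ccc(C(F)(F)F)cc1)n2C1CCCCC1`: compound 1 gives 35000 nM
- compound 2 `COc1ccc(-c2nc3cc(C(C)=O)ccc3n2C2CCCCC2)cc1`: compound 2 gives 30000 nM
- compound 3 `C/C(=N\NC(N)=S)c1ccc2c(c1)nc(-c1ccc(C(F)(F)F)cc1)n2C1CCCCC1`: for compound 3 the assay reports only a limit, > 100000 nM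

Compound 1 and compound 2 differ by methoxy in place of trifluoromethyl on an aromatic carbon; the step is a 1.2-fold lower number from compound 1 to compound 2 (0.07 log units; within the scatter). Compound 1 and compound 3 differ by a group of 7 heavy atoms (3 carbon, 3 nitrogen, 1 sulfur; no ring) in place of a group of 3 heavy atoms (2 carbon, 1 oxygen; no ring), on an aromatic carbon; the step is an at least 2.8-fold higher number from compound 1 to compound 3 (0.45 log units; beyond the scatter), and its size is open because of the limit of > 100000 nM in this assay, at which 1 of the 3 values shown sits.

Compound 4 `COc1ccc(-c2nc3cc(/C(C)=N/NC(N)=S)ccc3n2C2CCCCC2)cc1` is not yet measured. It differs from compound 3 by methoxy in place of trifluoromethyl on an aromatic carbon, the same change as between compound 1 and compound 2, made at the same place; the two cores differ as set out for compound 1 and compound 3.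

The step from compound 3 to compound 4 is expected to be a number no higher from compound 3 to compound 4 (the limit leaves the size open), resting on the measured step of a 1.2-fold lower number from compound 1 to compound 2 (0.07 log units; within the scatter). Compound 4 is thus expected at 100000 nM in this assay, between 50000 nM and 200000 nM, and may again come back as a limit.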

Compound 4, half-maximal cytotoxic concentration: 40000 nM
For compound 4 the middle estimate is 2.5-fold (0.40 log units) above the measured one, and the stated range ends above it.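

Methoxy in place of trifluoromethyl gives an at least 2.5-fold lower number from compound 3 to compound 4 (0.39 log units; beyond the scatter) in this assay, and on the methoxy side the larger group in place of the smaller one gives a 1.3-fold higher number from compound 2 to compound 4 (0.12 log units; within the scatter). The first change therefore lowers the number beyond the scatter on the core of compound 3, but this does not show that its size depends on the core: the same change on two cores in this assay, a 1.2-fold lower number (0.07 log units; within the scatter) from compound 1 to compound 2 and an at least 2.5-fold lower number (0.39 log units; beyond the scatter) from compound 3 to compound 4; the limit leaves it open whether they differ
The exchange of the larger group for the smaller one likewise gives no basis for saying that it carries over with the same size or with a different one: the same change on two cores in this assay, an at least 2.8-fold higher number (0.45 log units; beyond the scatter) from compound 1 to compound 3 and a 1.3-fold higher number (0.12 log units; within the scatter) from compound 2 to compound 4; the limit leaves it open whether they differ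

On these data alone, for compound 3, the assay gives only a limit, so the full size of both steps involving it stays open. The compounds shown also leave open how other groups at the same place on the aromatic ring, such as an amine, a carboxylic acid or a longer chain, would read in this assay on either core.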